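The source may hold more compounds than are shown below. What is called first, only, known or untested is meant among the compounds shown, and "the series" means these compounds.

In a functional assay on PC-3 cells (Homo sapiens) for inhibition, read by MTT assay, with a stated time of 72 h, tested at 10 uM (on this read-out lower numbers stand for less inhibition of growth and higher numbers for more inhibition of growth at the one concentration tested), compound 2 `COc1cc2ncnc(Nc3cc(F)ccc3Br)c2c(OC)c1OC` gives 34.7%. Compound 1 `COc1cc2ncnc(Nc3cc(C(F)(F)F)ccc3F)c2c(OC)c1OC` gives 29.2% in this assay. Compound 2 thus holds the higher of these two numbers, but the gap to compound 1 lies within the usual scatter, so the two cannot be told apart. Compound 3 `COc1cc2ncnc(Nc3cc(C(F)(F)F)ccc3Br)c2c(OC)c1OC` has not yet been measured. It differs from compound 2 by trifluoromethyl in place of fluoro on an aromatic carbon. Among the compounds with values here, no measured pair shows this single change on its own, so nothing points to a step beyond the scatter in either direction. Compound 3 is therefore expected to give about 33%, between 20% and 47%. The expected step of a number 1.7 percentage points lower from compound 2 to compound 3 (within the scatter) is estimated to stay within the scatter.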

Compound 3, percent growth inhibition at one concentration: 25.3%
Beside the measured number, compound 3's estimate is 7.7 percentage points above it, and the stated range covers the measured number.
By their numbers in this assay, from the lowest: compounds 3, 1 and 2 (each within the scatter of the next).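

In this assay trifluoromethyl in place of fluoro, para to the bromo group, gives a number 9.4 percentage points lower from compound 2 to compound 3 (within the scatter) and so does not separate these two groups at this position. With trifluoromethyl kept, bromo in place of fluoro on the other aromatic carbon gives a number 3.9 percentage points lower from compound 1 to compound 3 (within the scatter) and likewise separates nothing. No measured property of these groups bears on either step. As far as these compounds go, whether an amine or a carboxylic acid at the trifluoromethyl position would move the number beyond the scatter stays open. So does whether these groups differ at any other concentration.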